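Morpholine carboxamide on the nitro-bearing core

A few compounds are considered here, and "the series" means these few. Any claim that something is new, unique, unknown or untested is made for them only; others in the source may bear on it.

The series shares one thiourea core with a benzothiazole-type amine; the measured members are compound 1 `O=C(NC(=S)Nc1nc2cc([N+](=O)[O-])ccc2s1)c1ccccc1`, compound 2 `O=C(NC(=S)Nc1nc2ccccc2s1)N1CCOCC1` and compound 3 `O=C(NC(=S)Nc1nc2cc([N+](=O)[O-])ccc2s1)c1ccc([N+](=O)[O-])cc1`. In a functional assay on HeLa cells (Homo sapiens) for cytotoxicity, read by MTT assay, with a stated time of 24 h (a higher number here means a weaker inhibitor, a lower number a stronger inhibitor), compound 1 gives 75100 nM, compound 2 gives 51800 nM and compound 3 gives 68500 nM. Compound 3 cannot be set apart from either neighbour: its number lies within the scatter of compound 1 and within the scatter of compound 2, so the three measured values are indistinguishable on these data. Within the data shown here, the one step that stays inside the nitro-bearing core, a 1.1-fold lower number from compound 1 to compound 3 (0.04 log units; within the scatter), is also within the scatter.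

Compound 4 `O=C(NC(=S)Nc1nc2cc([N+](=O)[O-])ccc2s1)N1CCOCC1` is the untested member. Relative to compound 3 the change is morpholin-4-yl in place of 4-nitrophenyl on a carbonyl carbon. Among the measured compounds shown here, no measured pair isolates this exchange on the nitro-bearing core. For the measured compounds named here, compound 2 carries the same morpholin-4-yl group on the core without the nitro group and gives 51800 nM; compound 2 and compound 4 differ only in the nitro on an aromatic carbon, and the only measured step of that kind, a 1.1-fold lower number from compound 1 to compound 3 (0.04 log units; within the scatter), did not move the number beyond the scatter. The expected step of a 1.2-fold lower number from compound 3 to compound 4 (0.10 log units; within the scatter) is therefore small, with no direction beyond the scatter. The estimate for compound 4 in this assay is 55000 nM, in the range 30000 nM to 100000 nM.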

Compound 4, half-maximal inhibitory concentration: 54800 nM
The estimate for compound 4 lay 1.0-fold (0.00 log units) above the measured number, within the range that was stated.
By their numbers in this assay, from the lowest: compounds 2, 4, 3 and 1 (each within the scatter of the next).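

In this assay, the carbonyl position can now be read with a non-aromatic ring in place of an aromatic one. Morpholin-4-yl in place of 4-nitrophenyl on a carbonyl carbon gives a 1.3-fold lower number from compound 3 to compound 4 (0.10 log units; within the scatter), and morpholin-4-yl in place of phenyl on a carbonyl carbon gives a 1.4-fold lower number from compound 1 to compound 4 (0.14 log units; within the scatter), so neither exchange on the nitro-bearing core moves the number beyond the scatter. The nitro exchange on an aromatic carbon, earlier seen only with an aromatic group on the carbonyl carbon, now also has a reading with morpholin-4-yl there, a 1.1-fold higher number from compound 2 to compound 4 (0.02 log units; within the scatter), and the two readings agree: the same change on two cores in this assay, a 1.1-fold lower number (0.04 log units; within the scatter) from compound 1 to compound 3 and a 1.1-fold higher number (0.02 log units; within the scatter) from compound 2 to compound 4, 1.2-fold (0.06 log units) apart, within the scatter of two such steps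

On these data alone, it stays open whether any group on this carbonyl carbon can move the number in this assay beyond the scatter, and an open-chain amine, a longer chain or a phenyl carrying a carboxylic acid would test that. With all four compounds within the scatter of their neighbours, no group on the shared core can yet be tied to a change in the number.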